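Ester size and tolerated concentration in a shared-core series

The source may report more compounds than this note shows. Statements on the series, on what has been measured and on what is new or still open speak of the compounds shown alone.

Notes on the series: all three members carry the same core and differ only in the ester group. Compound 1 `CC(C)OC(=O)C(O)Cn1cnc2c(N)ncnc21` bears the isopropyl ester. In a functional assay on PRK cells (Oryctolagus cuniculus) for cytotoxicity (a lower number here means that less compound is tolerated, a higher number that more compound is tolerated), compound 1 gives > 400 ug/mL, which is a limit of the assay rather than a number. Compound 2 `CC(C)(C)OC(=O)C(O)Cn1cnc2c(N)ncnc21` bears the tert-butyl ester. In this assay compound 2 gives > 400 ug/mL, again a limit of the assay and not a number. Among the measured compounds shown here, the only measured step, a step that the two limits leave unreadable from compound 1 to compound 2, therefore has no readable size or direction, since both values sit at the limit of > 400 ug/mL in this assay, at which 2 of the 2 values shown sit. For the measured compounds named here, compound 2 thus stands at that limit, and the one further value shown is a limit as well.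

Compound 3 `CCOC(=O)C(O)Cn1cnc2c(N)ncnc21` carries the ethyl ester; against compound 2 the change is ethyl in place of tert-butyl on an oxygen next to a carbonyl group, that is tert-butoxy to ethoxy. Going by the values given here, the one step that bears on this change, a step that the two limits leave unreadable from compound 1 to compound 2, was itself unreadable, so no shift beyond the scatter is expected in this assay. Compound 3 is accordingly expected at 400 ug/mL, in the range 200 ug/mL to 400 ug/mL, most likely reported as a limit again. Compound 3 is expected to show a step of a number no higher from compound 2 to compound 3 (the limit leaves the size open).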

Compound 3, minimum cytotoxic concentration: > 400 ug/mL
Compound 3: only a limit was reported; the forecaster's own chance of this, stated with the estimate: 85%; the middle value sits exactly at the limit.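

No new step can be read, since compound 3 gives no readable step against compound 1 or compound 2, and all three compounds stand at one limit: the limit of > 400 ug/mL in this assay, at which 3 of the 3 values shown sit.

The compounds shown leave open whether the ethyl, isopropyl and tert-butyl esters differ at all in this assay, and at what concentration any of them becomes cytotoxic.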